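Ring-nitrogen substituents on the shared core: amide variation

A few compounds are considered here, and "the series" means these few. Any claim that something is new, unique, unknown or untested is made for them only; others in the source may bear on it.

Measured compounds in an assay on HEK293 cells for agonist activity at Toll-like receptor 8 (Homo sapiens), read by a luciferase reporter, with a stated time of 6 h; on this read-out lower numbers stand for an effect already at smaller amounts and higher numbers for an effect only at larger amounts of compound:
compound 1 `CCCCNc1nc(N)nc2c1CN(C)CC2` gives 0.03 uM
compound 2 `CCCCNc1nc(N)nc2c1CN(Cc1ccncc1)CC2` gives 0.29 uM
compound 3 `CCCCNc1nc(N)nc2c1CN(C(=O)C(C)C)CC2` gives 1.6 uM

Compound 3 stands at the highest number of the three in this assay, a modest distance from compound 2 and a large one from compound 1. The two steps that reach it, a 53-fold higher number from compound 1 to compound 3 (1.73 log units; beyond the scatter) and a 5.5-fold higher number from compound 2 to compound 3 (0.74 log units; beyond the scatter), both show the isopropylcarbonyl on the ring nitrogen as the least favourable of the three substituents tried there; the remaining step, a 9.7-fold higher number from compound 1 to compound 2 (0.99 log units; beyond the scatter), shows that a pyridin-4-yl group on the attached carbon is itself tolerated with only modest loss.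

Compound 4 `CCCCNc1nc(N)nc2c1CN(C(=O)c1ccccn1)CC2` keeps the carbonyl on the ring nitrogen and changes only what sits on it: pyridin-2-yl in place of isopropyl on a carbonyl carbon. For the measured compounds named here, no measured step touches the group on the carbonyl carbon, so the comparison is indirect. The carbonyl, which set the large loss in the step from compound 1 to compound 3, is retained; the pyridinyl ring, tolerated in compound 2, is the only new element. On this basis the step of a 1.1-fold lower number from compound 3 to compound 4 (0.03 log units; within the scatter) is expected to stay within the scatter or be at most modest, in either direction. Compound 4 is therefore estimated at 1.5 uM, within 0.5 uM to 5 uM.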

Compound 4, minimum effective concentration: 2.9 uM
Beside the measured number, compound 4's estimate is 1.9-fold (0.29 log units) below it; low and high end bracket the measured number.
By their numbers in this assay, from the lowest: compound 1; then compound 2; then compounds 3 and 4 (each within the scatter of the next).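

In this assay, for the compounds shown here, pyridin-2-yl in place of isopropyl on a carbonyl carbon gives a 1.8-fold higher number from compound 3 to compound 4 (0.26 log units; within the scatter) and so leaves the read-out within the scatter, the first change in this set to do so; the two amides cannot be separated in this assay, even though the entering group brings a six-membered aromatic ring and a hydrogen-bond acceptor that isopropyl lacks. Compound 4 also shares the distance of compound 3 from the two compounds without a carbonyl on the ring nitrogen, with a 10-fold higher number from compound 2 to compound 4 (1.00 log units; beyond the scatter) and a 97-fold higher number from compound 1 to compound 4 (1.99 log units; beyond the scatter) as the steps, so the unfavourable standing of compound 3 now recurs with a second, quite different group on the carbonyl carbon. No measurement shown here offers a reason for either observation.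

The compounds shown leave open whether any group on the carbonyl carbon can recover the low number of compound 1, for instance a methyl, a primary amine as in a urea, or a methoxy as in a carbamate. They also leave open how simple alkyl groups on the ring nitrogen, such as ethyl or a longer chain, compare with the methyl of compound 1.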